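Working notes: from compound 3 to compound 4

A few compounds are considered here, and "the series" means these few. Any claim that something is new, unique, unknown or untested is made for them only; others in the source may bear on it.

In an ADME assay on L929 cells (Mus musculus) for cytotoxicity, read by resazurin assay, with a stated time of 72 h (on this read-out higher numbers stand for weaker inhibition and lower numbers for stronger inhibition), compound 1 `CC(=O)c1ccn(-c2ccc3c(c2)B(O)OC3)c1` gives only a limit of > 10 ug/mL. Compound 2 `O=C(c1ccc(F)cc1)c1ccn(-c2ccc3c(c2)B(O)OC3)c1` likewise gives only a limit, > 10 ug/mL. Compound 3 `O=C(c1ccc(O)cc1)c1ccn(-c2ccc3c(c2)B(O)OC3)c1` also stops at a limit, > 10 ug/mL, so its place among the three cannot be ranked. The steps a step that the two limits leave unreadable from compound 1 to compound 2, a step that the two limits leave unreadable from compound 1 to compound 3 and a step that the two limits leave unreadable from compound 2 to compound 3 are unreadable in size; all that is shown is the limit of > 10 ug/mL in this assay, at which 3 of the 3 values shown sit. Compound 4 `NCc1ccc(C(=O)c2ccn(-c3ccc4c(c3)B(O)OC4)c2)cc1` differs from compound 3 by aminomethyl in place of hydroxy on an aromatic carbon. Among the measured compounds shown here, no measured step addresses this change, and none of the three has a readable size, so no direction beyond the scatter can be drawn from them. For compound 4 the expectation is that it, too, sits at the limit, a step that the limit leaves unreadable from compound 3 to compound 4 of no readable size, with an estimate of 15 ug/mL in the range 5 ug/mL to 50 ug/mL.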

Compound 4, half-maximal inhibitory concentration: > 10 ug/mL
Compound 4: no number, only a limit; the forecaster's own chance of this, stated with the estimate: 85%; the middle value does not contradict the limit.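

In this assay compound 4 gives > 10 ug/mL, a limit and not a number, so its steps from compound 1, compound 2 and compound 3 cannot be read. What stays open is whether these four compounds differ at all on this read-out: the limit of > 10 ug/mL in this assay, at which 4 of the 4 values shown sit.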